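Anilino substituent changes on the shared core: iodo for ethyl

A few compounds are considered here, and "the series" means these few. Any claim that something is new, unique, unknown or untested is made for them only; others in the source may bear on it.

Measured compounds and their values:
compound 1, `COc1cccc(NC2=CC(=O)c3c(nc4n3[C@H]3OC[C@@H](O)[C@H]3OC4)C2=O)c1`: > 8000 nM
compound 2, `O=C1C(NC2CCCC2)=CC(=O)c2c1nc1n2[C@H]2OC[C@@H](O)[C@H]2OC1`: > 16000 nM
compound 3, `CCc1ccc(NC2=CC(=O)c3c(nc4n3[C@H]3OC[C@@H](O)[C@H]3OC4)C2=O)cc1`: 6510 nM

Among the compounds with values here, in a functional assay on HeLa cells (Homo sapiens) for inhibition, read by sulforhodamine B assay (a lower number here means a stronger inhibitor, a higher number a weaker inhibitor), compound 3 gives 6510 nM and is the only compound of the three with a number. Compound 1 sits at a limit of this assay, > 8000 nM. Compound 2 likewise sits at a limit, > 16000 nM. The steps toward compound 3 therefore carry only floors: an at least 1.2-fold lower number from compound 1 to compound 3 (0.08 log units; that floor lies within the scatter) and an at least 2.4-fold lower number from compound 2 to compound 3 (0.39 log units; beyond the scatter). Between the two limits the step that the two limits leave unreadable from compound 1 to compound 2 cannot be read at all.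

Compound 4, `O=C1C(Nc2ccc(I)cc2)=CC(=O)c2c1nc1n2[C@H]2OC[C@@H](O)[C@H]2OC1`, keeps the amine and the aromatic ring of compound 3 and changes only the group on that ring: iodo in place of ethyl on an aromatic carbon. Within the data shown here, none of the measured steps exchanges one group on the ring for another; each swaps the whole substituent on the amine nitrogen, and two of the three values are limits. The measured steps thus give no direct guide to this change, and no step beyond the scatter is expected in this assay in either direction. Compound 4 is estimated at 5000 nM, with a range from 1500 nM to 16000 nM, which means an expected step of a 1.3-fold lower number from compound 3 to compound 4 (0.11 log units; within the scatter).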

Compound 4, half-maximal inhibitory concentration: 4010 nM
For compound 4 the middle estimate is 1.2-fold (0.10 log units) above the measured one; the measured number falls inside the stated range.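

Iodo in place of ethyl, para to a large group, gives a 1.6-fold lower number from compound 3 to compound 4 (0.21 log units; within the scatter) in this assay, so a single iodine atom and the two carbons of ethyl cannot be told apart at this place on the aromatic ring. Within the data shown here, this is the first exchange of one group on the ring for another, and the first pair with a number on both sides, whereas the earlier steps swapped the whole substituent on the amine nitrogen and mostly ended at limits. The new floors are an at least 3.9-fold lower number from compound 2 to compound 4 (0.60 log units; beyond the scatter) and an at least 1.9-fold lower number from compound 1 to compound 4 (0.29 log units; that floor lies within the scatter), and the one from compound 2 rests on a limit and not on a number: the limit of > 16000 nM in this assay, at which 1 of the 4 values shown sits.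

Going by these compounds, whether a carboxylic acid, an amine or a longer chain in place of iodo or ethyl would move the number beyond the scatter in this assay stays open. On these data alone, with the two numbers available lying within the scatter of each other, it also stays open whether this place on the ring responds to any exchange at all.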